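This account rests on a few compounds, and the source may have more. Where it says the series, first, only, none or still open, it means among the compounds named here.

Measured in an ADME assay on MT4 cells (Homo sapiens) for cytotoxicity; a lower number here means that less compound is tolerated, a higher number that more compound is tolerated:
- Compound 1 `O=C(NC(=S)Nc1cccc(C(F)(F)F)c1)c1ccccc1`: > 100000 nM
- Compound 2 `O=[N+]([O-])c1ccc(NC(=S)Nc2cccc(C(F)(F)F)c2)cc1`: 9200 nM
- Compound 3 `Cc1ccc(NC(=S)Nc2cccc(C(F)(F)F)c2)cc1Cl`: 20000 nM

Compound 1 has the entry > 100000 nM, which is a limit of the assay and not a number. Only the other two compounds therefore have numbers that can be compared directly. Compound 2 has the lower of these at 9200 nM, meaning that less of it is tolerated. Compound 3 gives 20000 nM, and this gap lies beyond the usual scatter.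

Compound 4 `Fc1ccc(NC(=S)Nc2cccc(C(F)(F)F)c2)cc1` has not yet been measured. It has fluoro in place of nitro on an aromatic carbon. Within the data shown here, no measured pair differs in just one place, so this expectation is only a rough one. Compound 3, which also has no nitro, gives 20000 nM, and this points towards a higher number than that of compound 2. The expected change is a 3.3-fold higher number from compound 2 to compound 4 (0.51 log units; beyond the scatter), a moderate step beyond the scatter towards greater tolerance. For compound 4 the estimated value is 30000 nM, with an expected range from 11000 nM to 90000 nM.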

Compound 4, half-maximal cytotoxic concentration: 31000 nM
Compound 4: middle estimate off by 1.0-fold (0.01 log units), on the low side; the measured number falls inside the stated range.
By their numbers in this assay, from the lowest: compound 2; then compounds 3 and 4 (each within the scatter of the next). At a limit, above all of these: compound 1.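

Among these compounds, this is the first step between two compounds that differ in one place only: fluoro in place of nitro on an aromatic carbon, para to a large group, gives in this assay a 3.4-fold higher number from compound 2 to compound 4 (0.53 log units; beyond the scatter). What sits at this position therefore matters to how much compound the cells tolerate, and of these two groups nitro is the one tolerated less. The step alone cannot show which difference between the two groups is responsible, and it applies to this position only.

On these data alone, whether an amine or a carboxylic acid at this position would move the number further, and in which direction, stays open. Compound 1 has a limit and not a number, so how high the number can go within this set remains unsettled: the limit of > 100000 nM in this assay, at which 1 of the 4 values shown sits.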